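Replacing a nitrile with trifluoromethoxy on a kinase inhibitor

The compounds below may be only part of what the source reports. "The series", "measured", "known", "first", "only" and "open" are said of these compounds alone.

Measured compounds:
Compound 1 `CC(=O)Nc1cccc(NC(=O)COc2ccc3c(=O)ccoc3c2)c1`: 136 nM
Compound 2 `O=C(COc1ccc2c(=O)ccoc2c1)Nc1cccc(NC(=O)c2ccc(Br)cc2)c1`: 49 nM
Compound 3 `N#Cc1ccc(C(=O)Nc2cccc(NC(=O)COc3ccc4c(=O)ccoc4c3)c2)cc1`: 15 nM

In an assay on isolated protein for inhibition of Rho-associated protein kinase 2 (Homo sapiens), read by scintillation counting, radiometric assay and 33P incorporation, with a stated time of 40 min, in the presence of a further agent that is not named here (on this read-out higher numbers stand for weaker inhibition and lower numbers for stronger inhibition), compound 3 gives the lowest number of the three, with a 3.3-fold lower number from compound 2 to compound 3 (0.51 log units; beyond the scatter) and a 9.1-fold lower number from compound 1 to compound 3 (0.96 log units; beyond the scatter) both beyond the scatter. Compound 4 `O=C(COc1ccc2c(=O)ccoc2c1)Nc1cccc(NC(=O)c2ccc(OC(F)(F)F)cc2)c1` is not yet measured; it differs from compound 3 by trifluoromethoxy in place of cyano on an aromatic carbon. Among the measured compounds shown here, no measured pair shows this exact swap. The closest guide is a 3.3-fold lower number from compound 2 to compound 3 (0.51 log units; beyond the scatter), where changing the group at the same place moved the number modestly, and a 2.8-fold lower number from compound 1 to compound 2 (0.44 log units; beyond the scatter) shows that a substituted ring there beats the simple methyl of compound 1. A modest move back toward compound 2 is therefore expected, a 2.7-fold higher number from compound 3 to compound 4 (0.43 log units; beyond the scatter), giving an estimate for compound 4 of 40 nM with a range of 12 nM to 130 nM.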

Compound 4, half-maximal inhibitory concentration: 77 nM
For compound 4 the middle estimate is 1.9-fold (0.28 log units) below the measured one; the range from low to high includes it.
By their numbers in this assay, from the lowest: compound 3; then compounds 2, 4 and 1 (each within the scatter of the next, the first and the last beyond it).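

Trifluoromethoxy does not stand in for the nitrile at this ring position, with a 5.1-fold higher number from compound 3 to compound 4 (0.71 log units; beyond the scatter). A substituted ring also no longer ensures a clear gain over the methyl of compound 1, since a 1.8-fold lower number from compound 1 to compound 4 (0.25 log units; within the scatter), while trifluoromethoxy and bromo cannot be told apart, with a 1.6-fold higher number from compound 2 to compound 4 (0.20 log units; within the scatter). Nothing measured here explains why the nitrile stands apart.

Going by these compounds, whether an amine, a carboxylic acid or a methoxy group at this place would match the nitrile remains open. So does whether the nitrile keeps its edge on a changed core.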